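A few compounds are considered here, and "the series" means these few. Any claim that something is new, unique, unknown or untested is made for them only; others in the source may bear on it.

Measured compounds:
Compound 1, `Cc1nn(-c2cccc3cc(Cc4cccc(C(F)(F)F)c4)sc23)cc1C(=O)NCCO`: 102%
Compound 2, `Cc1nn(-c2cccc3cc(Cc4cccc(C(F)(F)F)c4)sc23)c(C)c1C(=O)NCCO`: 110%
Compound 3, `COCCNC(=O)c1cnn(-c2cccc3cc(Cc4cccc(C(F)(F)F)c4)sc23)c1C`: 84%

All three were tested in a functional assay on CHO cells for agonist activity at G-protein coupled receptor 52 (Homo sapiens), read by AlphaScreen and cAMP accumulation, with a stated time of 30 min; on this read-out lower numbers stand for smaller maximal responses and higher numbers for larger maximal responses. Compound 2 and compound 1 share one core and differ by hydrogen in place of methyl on an aromatic carbon, a change that gave a number 8 percentage points lower from compound 2 to compound 1 (within the scatter). Compound 3 is built from the same atoms as compound 2, joined differently; the difference between the two cores is not broken down here. In this assay compound 3 stands lowest of the three, with compound 1 and compound 2 both higher beyond the scatter.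

Compound 4, `COCCNC(=O)c1cnn(-c2cccc3cc(Cc4cccc(C(F)(F)F)c4)sc23)c1`, has not yet been measured. It differs from compound 3 by hydrogen in place of methyl on an aromatic carbon. Going by the values given here, this is the same kind of change as the one from compound 2 to compound 1, though not the same: in compound 2 the place was also two ring bonds from the ring atom that bears a methyl group, which compound 3 lacks. For compound 4 a step of a number 6 percentage points lower from compound 3 to compound 4 (within the scatter) is expected, because the earlier change gave a number 8 percentage points lower from compound 2 to compound 1 (within the scatter). Compound 4 is therefore estimated at 78%, likely between 60% and 96%.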

Compound 4, largest response reached (Emax), in percent of the reference or control that the assay uses in the G-protein coupled receptor 52 assay: 81%
Estimate against measurement, compound 4: 3 percentage points below; low and high end bracket the measured number.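

In the G-protein coupled receptor 52 assay the swap of methyl for hydrogen gave a number 3 percentage points lower from compound 3 to compound 4 (within the scatter), and on these two cores the change carries over without a difference beyond the scatter, though two cores give no rule for any other core: the same change on two cores in the G-protein coupled receptor 52 assay, a number 8 percentage points lower (within the scatter) from compound 2 to compound 1 and a number 3 percentage points lower (within the scatter) from compound 3 to compound 4, 5 percentage points apart, within the scatter of two such steps

In a physicochemical assay for solubility, read by HPLC, at pH 6.8 (a lower number here means a less soluble compound, a higher number a more soluble compound), compound 3 gives 1.3 ug/mL. In the physicochemical assay compound 4 gives < 0.08 ug/mL, which is a limit of the assay and not a number.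

On these data alone, in the physicochemical assay the swap gave an at least 16-fold lower number from compound 3 to compound 4 (1.21 log units; beyond the scatter), but this step comes from a single core, so whether it recurs on the core of compound 1 stays open. Also open, as far as these compounds go, is how an ethyl group or a chlorine atom in the place of that methyl, or an amine at the end of the amide chain, would behave.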